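Halogenated phenyl variants on the shared core

The source may hold more compounds than are shown below. What is called first, only, known or untested is meant among the compounds shown, and "the series" means these compounds.

Compound 1 `COc1ccc(-c2ccc3ncn(-c4cc(OC)c(OC)c(OC)c4)c3c2)cc1O` gives 44 nM in a functional assay on SGC-7901 cells (Homo sapiens) for antiproliferative activity, read by MTT assay, with a stated time of 72 h; on this read-out higher numbers stand for weaker inhibition and lower numbers for stronger inhibition.
Compound 2 `COc1cc(-n2cnc3ccc(-c4cccc(Cl)c4)cc32)cc(OC)c1OC` gives 1490 nM.
Compound 3 `COc1cc(-n2cnc3ccc(-c4cccc(F)c4)cc32)cc(OC)c1OC` gives 2490 nM.

Compound 2 stands second highest of the three numbers; its nearest neighbour is compound 3, with a 1.7-fold higher number from compound 2 to compound 3 (0.22 log units; within the scatter), and its furthest is compound 1, with a 34-fold higher number from compound 1 to compound 2 (1.53 log units; beyond the scatter). The next compound, compound 4 `COc1cc(-n2cnc3ccc(-c4ccc(F)cc4)cc32)cc(OC)c1OC`, differs from compound 2 in one place: 4-fluorophenyl in place of 3-chlorophenyl on an aromatic carbon. Among the measured compounds shown here, the only step bearing directly on a halogen exchange is a 1.7-fold higher number from compound 2 to compound 3 (0.22 log units; within the scatter), within the scatter; a 57-fold higher number from compound 1 to compound 3 (1.75 log units; beyond the scatter) concerns a different exchange. For the measured compounds named here, no measured step moves a halogen from one position to another, so no step beyond the scatter is expected, with a slight lean toward a higher number. Compound 4 is estimated at 2000 nM, range 700 nM to 6000 nM, which is expected to mean a 1.3-fold higher number from compound 2 to compound 4 (0.13 log units; within the scatter).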

Compound 4, half-maximal inhibitory concentration: 3500 nM
For compound 4 the middle estimate is 1.8-fold (0.24 log units) below the measured one, within the range that was stated.
By their numbers in this assay, from the lowest: compound 1; then compounds 2, 3 and 4 (each within the scatter of the next, the first and the last beyond it).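

Exchanging 3-fluorophenyl for 4-fluorophenyl gives a 1.4-fold higher number from compound 3 to compound 4 (0.15 log units; within the scatter), so on this ring the two fluoro placements are not separated. Exchanging 3-chlorophenyl for 4-fluorophenyl gives a 2.3-fold higher number from compound 2 to compound 4 (0.37 log units; beyond the scatter), a modest step, but halogen and placement change together, so neither can be credited alone. The gap to the 3-hydroxy-4-methoxyphenyl compound also persists with this group, at an 80-fold higher number from compound 1 to compound 4 (1.90 log units; beyond the scatter).

Still open, as far as these compounds go, is whether an amine or a carboxylic acid on this phenyl would bring the number closer to that of compound 1. Nothing at hand explains these steps.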